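The source may hold more compounds than are shown below. What is called first, only, known or untested is meant among the compounds shown, and "the series" means these compounds.

Working notes on the series. Of the compounds shown here, two have been measured in an assay on CHO cells for displacement of a labelled ligand from prostaglandin E2 receptor EP3 subtype (Homo sapiens), read by radioligand binding; a lower number here means a stronger inhibitor, a higher number a weaker inhibitor. Compound 1 `CC(C)C(Nc1nnc[nH]1)c1ccc(-c2ccc3cccc(F)c3c2)[nH]c1=O` gives 22 nM. Among the compounds with values here, compound 2 `Cc1nc(C(c2ccc(-c3ccc4cccc(F)c4c3)[nH]c2=O)C(C)C)[nH]c1C` gives 7 nM, the lowest of the two numbers; the only measured step, a 3.1-fold lower number from compound 1 to compound 2 (0.50 log units; beyond the scatter), is modest. The unmeasured compound 3 `CC(C)C(c1cnc(N)s1)c1ccc(-c2ccc3cccc(F)c3c2)[nH]c1=O` differs from compound 2 by 2-amino-1,3-thiazol-5-yl in place of 4,5-dimethyl-1H-imidazol-2-yl on a saturated chain carbon bound to an aromatic carbon and a saturated chain carbon. Within the data shown here, the one measured step bears on it in that it also exchanges the aromatic ring on this saturated chain carbon, and there it changed the number only modestly. Two heterocycles at this carbon have so far given numbers within a modest span, so the third is expected to land near them, with a small step toward weaker binding thought somewhat more likely than further gain; the step of a 2.1-fold higher number from compound 2 to compound 3 (0.33 log units; beyond the scatter) is therefore expected to stay modest. Compound 3 is estimated at 15 nM in this assay, within a range of 5 nM to 45 nM.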

Compound 3, inhibition constant: 16 nM
Beside the measured number, compound 3's estimate is 1.1-fold (0.03 log units) below it; the range from low to high includes it.
By their numbers in this assay, from the lowest: compound 2; then compounds 3 and 1 (each within the scatter of the next).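

In this assay, the step of a 2.3-fold higher number from compound 2 to compound 3 (0.36 log units; beyond the scatter) is modest, so a third heterocycle with a different hetero atom set is accepted on this saturated chain carbon, while 4,5-dimethyl-1H-imidazol-2-yl remains the group with the lowest number, its steps to both other compounds lying beyond the scatter. The step of a 1.4-fold lower number from compound 1 to compound 3 (0.14 log units; within the scatter) lies within the scatter, so 2-amino-1,3-thiazol-5-yl and (4H-1,2,4-triazol-3-yl)amino cannot be told apart at this position. Nothing available explains the difference between these groups.

The compounds shown leave open whether this carbon needs a five-membered aromatic ring at all, or whether a plain amine or a carboxylic acid in its place would hold the number in this range. They also leave open whether the two methyl groups of the imidazole contribute to the lower number of compound 2, which the unsubstituted 1H-imidazol-2-yl group would test.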